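The source may hold more compounds than are shown below. What is called first, only, known or untested is meant among the compounds shown, and "the series" means these compounds.

Measured so far:
- compound 2 `CCCCCCNc1nc(-c2ccccc2)nc2c1nnn2Cc1ccccc1`: 13200000 nM
- compound 3 `OC1CCC(Nc2nc(-c3ccccc3)nc3c2nnn3Cc2ccccc2F)CC1`: 1850000 nM
- compound 1 `CNc1nc(-c2ccccc2)nc2c1nnn2Cc1ccccc1Cl`: 191000000 nM

In an assay on isolated protein for binding affinity to adenosine receptor A1 (Bos taurus) (on this read-out lower numbers stand for stronger inhibition and higher numbers for weaker inhibition), compound 2 holds the second highest of the three numbers; compound 3 sits at a lower number and compound 1 at a higher one, both gaps beyond the scatter. Compound 4 `CCCNc1nc(-c2ccccc2)nc2c1nnn2Cc1ccccc1` differs from compound 2 by hydrogen in place of propyl on a saturated chain carbon, three bonds along the chain from a nitrogen on an aromatic ring. Among the measured compounds shown here, no measured pair covers this change alone: compound 1, which also carries a shorter chain at the nitrogen on the aromatic ring, differs from compound 2 elsewhere as well, so its value cannot be tied to chain length. A modest rise in the number, or none beyond the scatter, is expected, the step being a 1.9-fold higher number from compound 2 to compound 4 (0.28 log units; within the scatter). Compound 4 is estimated at 25000000 nM, range 4000000 nM to 160000000 nM.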

Compound 4, inhibition constant: 37000000 nM
For compound 4 the middle estimate is 1.5-fold (0.17 log units) below the measured one; low and high end bracket the measured number.
By their numbers in this assay, from the lowest: compound 3; then compound 2; then compound 4; then compound 1.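

Among the compounds shown here, compound 2 and compound 4 form the first pair that differs in one place. In this assay the change from hexyl to propyl on the nitrogen on an aromatic ring gives a 2.8-fold higher number from compound 2 to compound 4 (0.45 log units; beyond the scatter) and shows that the number at this position responds modestly to chain length, with the hexyl compound holding the lower number. No measurement on hand explains this step.

One pair gives no trend. As far as these compounds go, how a chain longer than hexyl, or an amine or carboxylic acid on the chain, would read remains open.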